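The source may hold more compounds than are shown below. What is called first, only, known or untested is meant among the compounds shown, and "the series" means these compounds.

Measured so far:
- compound 1, `Cn1c(-c2ccccc2C(F)(F)F)nnc1C12CCC(CCS(C)(=O)=O)(CC1)CC2`: 96%
- compound 2, `CC(C)S(=O)(=O)CCC12CCC(c3nnc(-c4ccccc4C(F)(F)F)n3C)(CC1)CC2`: 88%
- compound 3, `CCS(=O)(=O)CCCCC12CCC(c3nnc(-c4ccccc4C(F)(F)F)n3C)(CC1)CC2`: 90%

In a functional assay on the whole organism (strain ICR) for inhibition, with Mus musculus as the target, with a stated time of 4 h, at a dose of 10 mg/kg by the oral route (a lower number here means less inhibition, a higher number more inhibition at the dose given (going by the name of the read-out)), compound 3 sits second of three numbers, with compound 2 nearest at a number 2 percentage points higher from compound 2 to compound 3 (within the scatter) and compound 1 furthest at a number 6 percentage points lower from compound 1 to compound 3 (within the scatter); all three values lie within the scatter of one another, so no order can be read among them.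

Compound 4, `CC(F)CCCC12CCC(c3nnc(-c4ccccc4C(F)(F)F)n3C)(CC1)CC2`, is not yet measured. It differs from compound 3 by 1-fluoroethyl in place of (ethylsulfonyl)methyl on a saturated chain carbon, three bonds along the chain from a saturated ring carbon. The measured steps that touch the same chain are a number 6 percentage points lower from compound 1 to compound 3 (within the scatter) and a number 2 percentage points higher from compound 2 to compound 3 (within the scatter), and a number 8 percentage points lower from compound 1 to compound 2 (within the scatter) alters only the group on the sulfonyl sulfur; every one of them keeps a sulfonyl group in place and none went beyond the scatter. Going by the values given here, no measured step removes the sulfonyl group, so the change to compound 4 is not covered by the steps seen. The expectation for this assay is therefore a step of a number 20 percentage points lower from compound 3 to compound 4 (beyond the scatter), held loosely and more likely downward than upward. For compound 4 the estimate in this assay is 70%, with a range from 35% to 95%.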

Compound 4, a percentage reported as inhibition, in the whole organism at one dose (the size of the read-out at that dose, not a potency): 96%
The estimate for compound 4 lay 26 percentage points below the measured number, and the stated range ends below it.
By their numbers in this assay, from the lowest: compounds 2, 3, 1 and 4 (each within the scatter of the next).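

In this assay, the sulfonyl group can leave the chain without a step beyond the scatter: with 1-fluoroethyl in place of (ethylsulfonyl)methyl, on a saturated chain carbon, three bonds along the chain from a saturated ring carbon, the step is a number 6 percentage points higher from compound 3 to compound 4 (within the scatter). The two other comparisons read the same way, with a number 8 percentage points higher from compound 2 to compound 4 (within the scatter) and no change at the digits printed from compound 1 to compound 4 (within the scatter), so among these four compounds a sulfonyl group is not required for a reading of this size at this one dose. No measurement bears on why the fluorinated chain and the sulfonyl chains read alike.

From the compounds shown here alone, the four readings do not separate at a single dose, so any difference in potency among them stays open. Also open, going by these compounds, is how this assay responds to a chain ending in an amine or a carboxylic acid, or to a plain unfluorinated alkyl chain.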